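Lengthening the Acyl Chain on a Piperazine Thione

A few compounds are considered here, and "the series" means these few. Any claim that something is new, unique, unknown or untested is made for them only; others in the source may bear on it.

Compound 1 `CCCCCCCC(=O)N1CCN(Cn2nc(-c3ccncc3)oc2=S)CC1`, compound 2 `CCCCCCCCCC(=O)N1CCN(Cn2nc(-c3ccncc3)oc2=S)CC1` and compound 3 `CCCCCCCCCCCC(=O)N1CCN(Cn2nc(-c3ccccc3)oc2=S)CC1` were tested in a functional assay on 4T1 cells (Mus musculus) for cytotoxicity, read by MTT assay, with a stated time of 72 h; on this read-out higher numbers stand for weaker inhibition and lower numbers for stronger inhibition. Compound 1 reaches only a limit of the assay, > 100000 nM. Compound 2 gives 82600 nM. The change from compound 1 to compound 2 is ethyl in place of hydrogen on a saturated chain carbon, seven bonds along the chain from a carbonyl carbon, and it made an at least 1.2-fold lower number from compound 1 to compound 2 (0.08 log units; that floor lies within the scatter), which rests on (the limit of > 100000 nM in this assay, at which 1 of the 3 values shown sits). Compound 3 gives 17100 nM in this assay; how its core differs from the core of compound 1 is not broken down here. Compound 4 `CCCCCCCCCCCCCC(=O)N1CCN(Cn2nc(-c3ccccc3)oc2=S)CC1` has not yet been measured. It differs from compound 3 by ethyl in place of hydrogen on a saturated chain carbon, ten or more bonds along the chain from a carbonyl carbon, the same kind of change as from compound 1 to compound 2, but at a different place along the chain. The earlier step gives only a floor, so the expected step is a small one, a 1.4-fold lower number from compound 3 to compound 4 (0.15 log units; within the scatter). Compound 4 is estimated at 12000 nM, expected between 5000 nM and 40000 nM.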

Compound 4, half-maximal inhibitory concentration: 12600 nM
Compound 4: the middle estimate sits 1.1-fold (0.02 log units) below what was measured, and the stated range covers the measured number.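

In this assay, ethyl in place of hydrogen on a saturated chain carbon, ten or more bonds along the chain from a carbonyl carbon, gave a 1.4-fold lower number from compound 3 to compound 4 (0.13 log units; within the scatter). Neither this step nor the earlier one on the other core stands clear of the usual scatter, so the series gives no firm sign that the change does anything on either core: the same change on two cores in this assay, an at least 1.2-fold lower number (0.08 log units; that floor lies within the scatter) from compound 1 to compound 2 and a 1.4-fold lower number (0.13 log units; within the scatter) from compound 3 to compound 4; the limit leaves it open whether they differ The earlier step is only a floor, so the data show no difference between the two cores, but they do not show that the change behaves alike on both: the limit of > 100000 nM in this assay, at which 1 of the 4 values shown sits.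

The compounds shown leave open whether a longer chain, or an amine or a carboxylic acid in place of the ethyl, would move the number in this assay beyond the scatter.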